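A few compounds are considered here, and "the series" means these few. Any claim that something is new, unique, unknown or untested is made for them only; others in the source may bear on it.

Measured so far in an assay on cells for inhibition of Ectonucleotide pyrophosphatase/phosphodiesterase family member 1 (Homo sapiens), with a stated time of 60 min, tested at 1 uM; on this read-out lower numbers stand for less inhibition and higher numbers for more inhibition at the one concentration tested (going by the name of the read-out): compound 1 `COc1cc2ncnc(N3CCC(CCNS(C)(=O)=O)CC3)c2cc1OC` gives 12%, and compound 2 `COc1cc2ncnc(N3CCC(CO)CC3)c2cc1OC` gives 11%. Compound 3 `COc1cc2ncnc(N3CCC(CC#N)CC3)c2cc1OC` gives only a limit of the assay, < 1%, not a number (the limit of < 1% in this assay, at which 1 of the 3 values shown sits).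

Compound 3 thus stands at the floor of the values shown: a number at least 11 percentage points lower from compound 1 to compound 3 (beyond the scatter), and a number at least 10 percentage points lower from compound 2 to compound 3 (that floor lies within the scatter), whereas a number 1 percentage points lower from compound 1 to compound 2 (within the scatter).

Compound 4 `COc1cc2ncnc(N3CCC(CCN)CC3)c2cc1OC` differs from compound 3 by aminomethyl in place of cyano on a saturated chain carbon bound to a saturated ring carbon. The two measured steps that reach compound 3 each replaced a chain carrying a hydrogen-bond donor with cyano, and the numbers went down. Reversing that kind of swap is expected to lift the reading in this assay, a number at least 9 percentage points higher from compound 3 to compound 4 (that floor lies within the scatter). Compound 4 is therefore estimated at 10%, with a range from 1% to 20%.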

Compound 4, a percentage reported as inhibition, at one concentration (the size of the read-out at that concentration, not a potency): 45%
Estimate against measurement, compound 4: 35 percentage points below, and the stated range ends below it.
By their numbers in this assay, from the lowest: compounds 2 and 1 (each within the scatter of the next); then compound 4. At a limit, below all of these: compound 3.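

In this assay, this place on the chain proves highly sensitive to the group at its end: there is a number 34 percentage points higher from compound 2 to compound 4 (beyond the scatter), and a number 33 percentage points higher from compound 1 to compound 4 (beyond the scatter). Compound 1 and compound 2 also carry a hydrogen-bond donor on the chain, so such a donor alone does not bring the higher reading seen with the free amine of compound 4. Replacing the nitrile gives a number at least 44 percentage points higher from compound 3 to compound 4 (beyond the scatter), but this step is only a floor, as compound 3 gives a limit and not a number: the limit of < 1% in this assay, at which 1 of the 4 values shown sits.

Going by these compounds, it remains open whether a dimethylamine or a longer chain ending in an amine would keep this reading. A carboxylic acid at the same place is also untested among the compounds shown.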